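Solubility after trading an oxazole for a cyanophenyl

The source may hold more compounds than are shown below. What is called first, only, known or untested is meant among the compounds shown, and "the series" means these compounds.

Compound 1 `COc1cccc(NC(=O)c2nnn(Cc3cc(C)on3)c2N)c1` stands at the top of the three measured compounds: in a physicochemical assay for solubility, read by nephelometry, at pH 7.4 (a higher number here means a more soluble compound, a lower number a less soluble compound), compound 1 gives 174000 nM. Compound 2 `COc1cccc(NC(=O)c2nnn(Cc3ccc(-n4cccn4)cc3)c2N)c1` gives 20000 nM, and compound 3 `COc1cccc(NC(=O)c2nnn(Cc3ccccc3)c2N)c1` gives 16000 nM. Compound 4 `COc1cccc(NC(=O)c2nnn(Cc3ccc(C#N)cc3)c2N)c1` has not yet been measured; it differs from compound 1 in a single place: 4-cyanophenyl in place of 5-methyl-1,2-oxazol-3-yl on a saturated chain carbon bound to an aromatic nitrogen.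

The measured step that bears most directly on this change is the one in which a plain phenyl takes the place of the same 5-methyl-1,2-oxazol-3-yl on the saturated chain carbon bound to an aromatic nitrogen, and there an 11-fold lower number from compound 1 to compound 3 (1.04 log units; beyond the scatter). The second step shows what happens when a substituent is added to that phenyl: between compound 2 and compound 3 a 1.3-fold lower number from compound 2 to compound 3 (0.10 log units; within the scatter), so a group on the phenyl hardly moved the number. Compound 4 carries a 4-cyanophenyl, that is, a phenyl with a nitrile, and the expectation is therefore a large downward step in this assay of about the size seen for compound 3, with the nitrile making little further difference.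

Compound 4 is expected to give 15000 nM, within a range from 5000 nM to 45000 nM. That estimate means an expected step of a 12-fold lower number from compound 1 to compound 4 (1.06 log units; beyond the scatter).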

Compound 4, solubility: 216000 nM
For compound 4 the middle estimate is 14-fold (1.16 log units) below the measured one, and the stated range ends below it.
By their numbers in this assay, from the lowest: compounds 3 and 2 (each within the scatter of the next); then compounds 1 and 4 (each within the scatter of the next).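

In this assay, placing 4-cyanophenyl instead of 5-methyl-1,2-oxazol-3-yl on the saturated chain carbon bound to an aromatic nitrogen gives a 1.2-fold higher number from compound 1 to compound 4 (0.09 log units; within the scatter), so a six-membered aromatic ring of carbon only at this position does not always go with the large drop seen for the plain phenyl. The group on that phenyl can matter a great deal, which the earlier pair with hydrogen and 1H-pyrazol-1-yl did not reveal: cyano in place of hydrogen gives a 14-fold higher number from compound 3 to compound 4 (1.13 log units; beyond the scatter), and cyano in place of 1H-pyrazol-1-yl gives an 11-fold higher number from compound 2 to compound 4 (1.03 log units; beyond the scatter). Nothing measured here explains why the nitrile stands apart from the other two groups.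

Going by these compounds, it remains open whether a carboxylic acid, an amine or a methoxy group on the same phenyl would give a high number like that of compound 4 or a low one like that of compound 3. It is also unknown whether cyano in place of hydrogen would give a step of similar size on a core other than the one shared by these four compounds.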